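A ring exchange on the carbonyl: compound 3 to compound 4

The source may hold more compounds than are shown below. What is called first, only, known or untested is meant among the compounds shown, and "the series" means these compounds.

Three compounds share one core and were tested in a functional assay on RAW264.7 cells (Mus musculus) for inhibition, read by Griess assay, with a stated time of 24 h; on this read-out lower numbers stand for stronger inhibition and higher numbers for weaker inhibition. Compound 1 `O=C(S[C@]12CC[C@@H](O)[C@H]1C(=O)NC2=O)c1ccc(O)cc1` gives 42000 nM. Compound 2 `O=C(SC12CCC(O)C1C(=O)NC2=O)c1ccc(O)cc1` gives 225000 nM. Compound 3 `O=C(S[C@]12CC[C@H](O)[C@H]1C(=O)NC2=O)c1ccc(O)cc1` gives 141000 nM. On these numbers compound 3 stands second highest of the three: the step of a 1.6-fold lower number from compound 2 to compound 3 (0.20 log units; within the scatter) lies within the scatter, whereas a 3.4-fold higher number from compound 1 to compound 3 (0.53 log units; beyond the scatter) and a 5.4-fold higher number from compound 1 to compound 2 (0.73 log units; beyond the scatter) lie beyond it. Those two larger steps rest on the fact that compounds 1 and 3 differ only in the configuration as drawn and on (the fact that one of compounds 1 and 2 is drawn with a defined configuration and the other without, at the place where they differ), so every measured step concerns only the drawn configuration of the core.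

Compound 4 `O=C(S[C@]12CC[C@H](O)[C@H]1C(=O)NC2=O)c1cccs1` departs from compound 3 by thiophen-2-yl in place of 4-hydroxyphenyl on a carbonyl carbon. For the measured compounds named here, none of the measured steps involves a change of this kind, so they offer no guide to its size or direction. The expectation therefore rests on compound 3 alone: compound 4 is expected to lie near it, and the step of a 1.1-fold higher number from compound 3 to compound 4 (0.03 log units; within the scatter) is expected to fall within the scatter, with a wide margin of uncertainty in both directions. For compound 4 the estimated value is 150000 nM, in a range from 40000 nM to 550000 nM.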

Compound 4, half-maximal inhibitory concentration: 36600 nM
The estimate for compound 4 lay 4.1-fold (0.61 log units) above the measured number; the measured number lies below the stated range.
By their numbers in this assay, from the lowest: compounds 4 and 1 (each within the scatter of the next); then compounds 3 and 2 (each within the scatter of the next).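

In this assay, the exchange of 4-hydroxyphenyl for thiophen-2-yl on the carbonyl carbon gives a step beyond the scatter (a 3.9-fold lower number from compound 3 to compound 4 (0.59 log units; beyond the scatter)), the first sign that the number responds to this group and not only to the drawn configuration of the shared core. The change also alters more than one feature at once: the ring goes from six-membered to five-membered, a ring sulfur enters, and the hydrogen-bond donor of the leaving group is lost. Nothing known about these compounds bears on why the number falls with this exchange.

The compounds shown leave open which of these features carries the step, a question that plain phenyl, 4-methoxyphenyl or furan-2-yl on the same carbonyl carbon could address. They also leave open whether thiophen-2-yl has a similar effect on the configuration of compound 1.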